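The compounds below may be only part of what the source reports. "The series", "measured", "known", "first", "only" and "open" are said of these compounds alone.

Compound 2 `CCCCCOc1nc(N)nc2c1ncn2/C=C1/CC1(CO)CO` and compound 1 `CCCNc1nc(N)nc2c1ncn2/C=C1/CC1(CO)CO` share a core that is also carried by compound 3 `Nc1nc2c(ncn2/C=C2/CC2(CO)CO)c(=O)[nH]1` and by the still unmeasured compound 4 `Nc1nc(SC2CCCC2)c2ncn(/C=C3/CC3(CO)CO)c2n1`. In an ADME assay on CCRF-HSB-2 cells (Homo sapiens) for cytotoxicity, with a stated time of 7 days (on this read-out lower numbers stand for higher toxicity in this test and higher numbers for lower toxicity in this test), compound 2 gives only the assay limit, > 20000 nM. Compound 1 likewise returns only the limit, > 20000 nM. Compound 3 also sits at the limit, > 20000 nM. Going by the values given here, the single measured step, a step that the two limits leave unreadable from compound 1 to compound 2, therefore cannot be read, since (the limit of > 20000 nM in this assay, at which 3 of the 3 values shown sit). Compound 4 differs from compound 2 by cyclopentylsulfanyl in place of pentyloxy on an aromatic carbon. Among the compounds with values here, no measured step bears readably on this change, so no step beyond the scatter is expected, and compound 4 is most likely to return the limit once more. The estimate for compound 4 is 25000 nM, with a range of 8000 nM to 80000 nM, expected as a step that the limit leaves unreadable from compound 2 to compound 4.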

Compound 4, half-maximal cytotoxic concentration: 91000 nM
For compound 4 the middle estimate is 3.6-fold (0.56 log units) below the measured one; measured number outside the range, above it.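

No step to compound 4 can be read from compound 1 or compound 2, since both of those compounds sit at a limit: the limit of > 20000 nM in this assay, at which 3 of the 4 values shown sit.

The compounds shown leave open the size of the change from pentyloxy or propylamino to cyclopentylsulfanyl.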